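Shifting a Methyl Group: From Compound 2 to Compound 3

The source may report more compounds than this note shows. Statements on the series, on what has been measured and on what is new or still open speak of the compounds shown alone.

Measured compounds:
Compound 1, `CS(=O)(=O)c1ccc(-c2cnc3[nH]cc(-c4nnc(-c5ccncc5)o4)c(=O)c3c2)cc1`: in a functional assay on HepG2 cells (Homo sapiens) for inhibition, read by MTT assay, with a stated time of 24 h, tested at 5 uM (a lower number here means less inhibition of growth, a higher number more inhibition of growth at the concentration tested), compound 1 gives 3.49%.
Compound 2, `Cc1ccc(-c2nnc(-c3c[nH]c4ncc(-c5ccc(S(C)(=O)=O)cc5)cc4c3=O)o2)cc1`: in this assay compound 2 gives 6.9%.

For the measured compounds named here, compound 2 and compound 1 lie within the usual scatter of each other; the only measured step, a number 3.4 percentage points higher from compound 1 to compound 2 (within the scatter), is small. Compound 3, `Cc1cccc(-c2nnc(-c3c[nH]c4ncc(-c5ccc(S(C)(=O)=O)cc5)cc4c3=O)o2)c1`, differs from compound 2 by 3-methylphenyl in place of 4-methylphenyl on an aromatic carbon. Going by the values given here, no measured step moves a methyl group around the same ring, so no step bears directly on this change. Among the compounds with values here, since the one known change near this position stayed within the scatter, compound 3 is expected to stay near compound 2, an estimated step of a number 0.9 percentage points lower from compound 2 to compound 3 (within the scatter). The expected value for compound 3 is 6%, with a range from 0% to 18%.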

Compound 3, percent growth inhibition at one concentration: 13.2%
Compound 3: middle estimate off by 7.2 percentage points, on the low side, within the range that was stated.
By their numbers in this assay, from the lowest: compounds 1, 2 and 3 (each within the scatter of the next).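

Moving the methyl group from 4-methylphenyl to 3-methylphenyl leaves the reading within the scatter (a number 6.3 percentage points higher from compound 2 to compound 3 (within the scatter)), so at this position the shift produces no change that can be told apart from repeat variation. Replacing pyridin-4-yl with 3-methylphenyl also stays within the scatter (a number 9.7 percentage points higher from compound 1 to compound 3 (within the scatter)), so compounds 1 and 3 cannot be separated either. Nothing available here bears on these small differences.

Still open, from the compounds shown here alone, is whether an amine or a carboxylic acid on this phenyl ring, or a longer chain in place of the methyl group, would carry the number beyond the scatter.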